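The compounds below may be only part of what the source reports. "The series", "measured", "known", "first", "only" and "open" are said of these compounds alone.

Compound 1, `O=C(Nc1ccccn1)c1c(O)c2cccnc2n(-c2ccccc2)c1=O`, gives 14.6% in a functional assay on the whole organism for inhibition, with Rattus norvegicus as the target, read by cytopathic effect and paw edema, at a dose of 100 mg/kg by the oral route; a higher number here means more inhibition at the dose given (going by the name of the read-out), a lower number less inhibition.
Compound 2, `COc1ccc(NC(=O)c2c(O)c3cccnc3n(-c3ccccc3)c2=O)cc1`, gives -1.9% in this assay.
Compound 3, `O=C(Nc1cccc([N+](=O)[O-])c1)c1c(O)c2cccnc2n(-c2ccccc2)c1=O`, gives 7.4% in this assay.

Compound 2 stands lowest of the three numbers in this assay; its nearest neighbour is compound 3, and the gap between them, a number 9.3 percentage points higher from compound 2 to compound 3 (within the scatter), is within the scatter, while the gap to compound 1, seen as a number 16.5 percentage points lower from compound 1 to compound 2 (beyond the scatter), is beyond it. The unmeasured compound 4, `O=C(Nc1ccc(Cl)nc1)c1c(O)c2cccnc2n(-c2ccccc2)c1=O`, differs from compound 2 in one place: 6-chloropyridin-3-yl in place of 4-methoxyphenyl on an amide-type nitrogen.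

Within the data shown here, two measured steps bear on this change, both exchanging the group on the amide-type nitrogen of compound 2. Replacing pyridin-2-yl with 4-methoxyphenyl gave a number 16.5 percentage points lower from compound 1 to compound 2 (beyond the scatter), and replacing 4-methoxyphenyl with 3-nitrophenyl gave a number 9.3 percentage points higher from compound 2 to compound 3 (within the scatter). Compound 4 carries a six-membered aromatic ring with one hetero atom, as compound 1 does, though not the same ring. A rise from compound 2 is therefore expected in this assay, of about the size seen in compound 1, though possibly within the scatter. The step from compound 2 to compound 4 is estimated as a number 9.9 percentage points higher from compound 2 to compound 4 (within the scatter). For compound 4 the estimate is 8%, with a range from -5% to 20%.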

Compound 4, a percentage reported as inhibition, in the whole organism at one dose (the size of the read-out at that dose, not a potency): -4%
For compound 4 the middle estimate is 12 percentage points above the measured one; the measured number falls inside the stated range.
By their numbers in this assay, from the lowest: compounds 4, 2, 3 and 1 (each within the scatter of the next, the first and the last beyond it).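

In this assay, the change to 6-chloropyridin-3-yl on an amide-type nitrogen gives a number 2.1 percentage points lower from compound 2 to compound 4 (within the scatter) and so shows that a six-membered aromatic ring with one hetero atom at this place does not by itself set a compound apart from the 4-methoxyphenyl compound. The same group gives a number 18.6 percentage points lower from compound 1 to compound 4 (beyond the scatter) and a number 11.4 percentage points lower from compound 3 to compound 4 (beyond the scatter) on this nitrogen, which means that the number seen with the pyridin-2-yl group of compound 1 does not carry over to every ring of this kind. Nothing measured here offers a reason for the difference between these two rings.

The compounds shown leave open whether the chlorine of compound 4 or the place of the ring nitrogen accounts for that difference, a question that a plain pyridin-3-yl group on the same nitrogen would help to separate. They also leave open how this position responds to a carboxylic acid or an amine on the ring, or to a saturated ring such as cyclohexyl in place of the aromatic one.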